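Adding a hydroxyl chain to the methylamino group of compound 1

A few compounds are considered here, and "the series" means these few. Any claim that something is new, unique, unknown or untested is made for them only; others in the source may bear on it.

Of the compounds shown here, three sharing one core have been measured in an assay on isolated protein for binding affinity to adenosine receptor A1 (Bos taurus); a lower number here means a stronger inhibitor, a higher number a weaker inhibitor. Compound 1 `CNc1nc(-c2ccccc2)nc2c1nnn2Cc1ccccc1Cl` gives 191000000 nM, the highest of the three numbers. Going by the values given here, compound 2 `CNc1nc(-c2ccccc2)nc2c1nnn2Cc1ccccc1F` gives 25000000 nM, and the only single-change step among the measured compounds, a 7.6-fold lower number from compound 1 to compound 2 (0.88 log units; beyond the scatter), is the replacement of chloro by fluoro on an aromatic carbon. Compound 3 `CCCCNc1nc(-c2ccccc2)nc2c1nnn2Cc1ccccc1` gives 11000000 nM; it differs from compound 1 in two places at once, so only its number can be set beside that of compound 1, where it shows the lowest value of the set.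

Compound 4 `CC(O)CNc1nc(-c2ccccc2)nc2c1nnn2Cc1ccccc1Cl` has not yet been measured. It differs from compound 1 by 1-hydroxyethyl in place of hydrogen on a saturated chain carbon bound to a nitrogen on an aromatic ring, which at the next bond out reads as methylamino to (2-hydroxypropyl)amino. Among the compounds with values here, no measured step alters this part of the molecule alone, so the expectation rests on the wider picture: every change away from compound 1 so far has lowered the number, and compound 3, carrying a longer chain on the ring nitrogen, gives 11000000 nM. Compound 4 is therefore expected to show a modest decrease, a 3.2-fold lower number from compound 1 to compound 4 (0.50 log units; beyond the scatter), and is estimated at 60000000 nM, with a range from 10000000 nM to 300000000 nM.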

Compound 4, inhibition constant: 32000000 nM
Beside the measured number, compound 4's estimate is 1.9-fold (0.27 log units) above it; the range from low to high includes it.
By their numbers in this assay, from the lowest: compound 3; then compounds 2 and 4 (each within the scatter of the next); then compound 1.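

In this assay, going by these compounds alone, the step of a 6.0-fold lower number from compound 1 to compound 4 (0.78 log units; beyond the scatter) is the first reading of a change to this part of compound 1 taken alone, and it lies beyond the scatter. Until now, this part could be seen only through compound 3, which differs from compound 1 in two places, whereas methylamino to (2-hydroxypropyl)amino is a single change with the chloro group left as it stands. No evidence is available to explain why this change moves the number as it does.

The chain and its hydroxyl enter together, so these compounds cannot show how much of the step belongs to the added carbons and how much to the hydroxyl; a plain propyl chain on the same nitrogen would separate the two, and an amine or a carboxylic acid in place of the hydroxyl would show whether the group at the chain end matters at all. Also open, going by these compounds, is whether this change and the replacement of chloro by fluoro would add up in a single compound carrying both the (2-hydroxypropyl)amino and fluoro groups.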